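The source may hold more compounds than are shown below. What is called first, only, known or untested is meant among the compounds shown, and "the series" means these compounds.

Compound 1, `COc1cc(NC(C)CCCNC(=O)NN)c2ncccc2c1`: >= 250000 nM
Compound 2, `NNC(=O)NC(c1ccccc1)c1ccc(Cl)cc1`: 182000 nM

Of the compounds shown here, two have been measured in a functional assay on HeLa cells (Homo sapiens) for inhibition, read by MTT assay, with a stated time of 4 days; a higher number here means a weaker inhibitor, a lower number a stronger inhibitor. Compound 1 reaches only a limit of the measurement rather than a number: in this assay compound 1 gives >= 250000 nM. All that can be said of compound 1 is the limit of >= 250000 nM in this assay, at which 1 of the 2 values shown sits. For the measured compounds named here, compound 2 differs from compound 1 in more than one place, so no single step between them can be drawn; in this assay compound 2 gives 182000 nM, a number, and a very weak one.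

Compound 3, `COc1cc(NC(C)CCCNC(=O)NNC(=O)NC(CO)(CO)CO)c2ncccc2c1`, is compound 1 with one change: (2-hydroxy-1,1-bis(hydroxymethyl)ethyl)carbamoyl in place of hydrogen on an amine nitrogen. Because compound 1 stands at the limit of >= 250000 nM in this assay, at which 1 of the 2 values shown sits, there is no measured number to move from. Going by the values given here, no measured pair here shows what a change of this kind does, so the expected step, a number no higher from compound 1 to compound 3 (the limit leaves the size open), is none beyond the usual scatter. Compound 3 is therefore expected to give around 250000 nM in this assay, within a range from 90000 nM to 700000 nM, and it may well again come out only as a limit.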

Compound 3, half-maximal inhibitory concentration: > 250000 nM
Compound 3: no number, only a limit (the forecaster's own chance of this, stated with the estimate: 65%); the middle value sits exactly at the limit.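

In this assay compound 3 gives > 250000 nM, which is a limit and not a number. For the compounds shown here, compound 1 also gives only a limit, >= 250000 nM, so no step from compound 1 to compound 3 can be read. From the compounds shown here alone, what (2-hydroxy-1,1-bis(hydroxymethyl)ethyl)carbamoyl in place of hydrogen does to the strength of inhibition remains open.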